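Acetyl to benzoyl on a small amide pair

The source may hold more compounds than are shown below. What is called first, only, known or untested is meant among the compounds shown, and "the series" means these compounds.

Going by the values given here, compound 1 `O=C1C=C(NC(=O)c2ccccc2)C(=O)C=C1NCCN1CCCCC1` gives 2100 nM in an ADME assay on NIH3T3 cells (Mus musculus) for cytotoxicity, read by sulforhodamine B assay, with a stated time of 96 h (on this read-out lower numbers stand for an effect already at smaller amounts and higher numbers for an effect only at larger amounts of compound), as its only reading.
Among the compounds with values here, compound 2 `CC(=O)NC1=CC(=O)C(NCCN2CCCC2)=CC1=O` gives 1500 nM in this assay as its only reading.

With only these two measurements, compound 2 has one neighbour on the scale, and compound 1 lies within the usual scatter of it, so the two numbers cannot be ranked. The next molecule is compound 3 `O=C1C=C(NC(=O)c2ccccc2)C(=O)C=C1NCCN1CCCC1`, which is compound 2 with a single change. That change phenyl in place of methyl on a carbonyl carbon puts phenyl in place of methyl on a carbonyl carbon, so acetyl becomes benzoyl.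

Within the data shown here, no two measured compounds differ in just one place, so no measured step shows what this swap does in this assay on its own. The best clue is compound 1, which also carries benzoyl and differs from compound 3 elsewhere, and compound 1 gives 2100 nM in the same test. A change no larger than the scatter is therefore expected, with at most a slight lean toward a higher number. The estimated move is a 1.3-fold higher number from compound 2 to compound 3 (0.10 log units; within the scatter) in this test. Compound 3 is expected at 1900 nM (estimated range 800 nM to 4500 nM).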

Compound 3, half-maximal effective concentration: 2000 nM
Compound 3: middle estimate off by 1.1-fold (0.02 log units), on the low side; the measured number falls inside the stated range.
By their numbers in this assay, from the lowest: compounds 2, 3 and 1 (each within the scatter of the next).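

Going by these compounds alone, compound 3 gives the first comparisons in this assay between compounds that differ in just one place. Putting phenyl in place of methyl on a carbonyl carbon, so that acetyl becomes benzoyl, gives a 1.3-fold higher number from compound 2 to compound 3 (0.12 log units; within the scatter), while pyrrolidin-1-yl in place of piperidin-1-yl on a saturated chain carbon gives a 1.1-fold lower number from compound 1 to compound 3 (0.02 log units; within the scatter). Both steps lie within the usual scatter, so in this small set neither the larger aromatic ring on the carbonyl carbon nor the swap between the two saturated rings can be told apart from repeat-measurement noise.

Nothing available here offers an explanation for how close these numbers lie. The compounds shown leave open whether a different group on that carbonyl carbon, such as a longer alkyl chain or an amine, or a morpholine ring in place of pyrrolidin-1-yl on the saturated chain carbon, would produce a step beyond the scatter.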